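The compounds below may be only part of what the source reports. "The series", "measured", "known", "first", "only" and "open" are said of these compounds alone.

Compound 1 `C=C1[C@@H](OC(C)=O)C[C@@H]2[C@](C)(COC=O)[C@H](OC(C)=O)CC[C@@]2(C)[C@@H]1C[C@@H](Nc1ccccc1F)C1=CCOC1=O`: 29000 nM
Compound 2 `C=C1[C@@H](C/C=C2/C(=O)OC[C@H]2OC(C)=O)[C@]2(C)CC[C@@H](OC(C)=O)[C@@](C)(CO[Si](C)(C)C(C)(C)C)[C@H]2C[C@@H]1O`: 9790 nM

In a functional assay on KB cells (Homo sapiens) for cytotoxicity, read by sulforhodamine B assay (on this read-out higher numbers stand for weaker inhibition and lower numbers for stronger inhibition), compound 1 stands at 29000 nM, the higher of the two numbers and so the weaker inhibition. Compound 2 lies lower at 9790 nM, and this gap is beyond the scatter. Among the compounds with values here, the two compounds differ in more than one place, so no measured step isolates a single change.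

Within the data shown here, compound 3 `C=C1[C@@H](OC(C)=O)C[C@@H]2[C@](C)(COC=O)[C@H](OC(C)=O)CC[C@@]2(C)[C@@H]1C[C@@H](Nc1cccc2ccccc12)C1=CCOC1=O` keeps the core of compound 1 and changes only one group: naphthalen-1-yl in place of 2-fluorophenyl on an amine nitrogen. No measurement in the series yet shows what a change at this amine does. In this assay a moderate step toward a lower number is expected, and it may prove small: the estimated step is a 2.2-fold lower number from compound 1 to compound 3 (0.35 log units; beyond the scatter). The expected value for compound 3 is 13000 nM, with an estimated range of 4500 nM to 38000 nM.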

Compound 3, half-maximal inhibitory concentration: 32300 nM
Compound 3: the middle estimate sits 2.5-fold (0.40 log units) below what was measured, and the stated range covers the measured number.
By their numbers in this assay, from the lowest: compound 2; then compounds 1 and 3 (each within the scatter of the next).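

In this assay, within the data shown here, naphthalen-1-yl in place of 2-fluorophenyl on an amine nitrogen gives a 1.1-fold higher number from compound 1 to compound 3 (0.05 log units; within the scatter) and is the only measured step at this position. Going from one six-membered aromatic ring carrying fluorine to two six-membered aromatic rings of carbon only therefore does not separate compound 1 from compound 3 on this read-out, so this position tolerates the exchange without a measurable change in this pair. Nothing measured here bears on why the number holds.

From the compounds shown here alone, whether this nitrogen responds at all to other kinds of group stays open, for example a saturated cyclohexyl ring, a phenyl ring bearing a carboxylic acid, or a longer alkyl chain. Compound 2 differs from these compounds in more than one place and cannot settle that question.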